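The source may report more compounds than this note shows. Statements on the series, on what has been measured and on what is new or still open speak of the compounds shown alone.

Compound 1 `CN1Cc2ccc(OCc3ccccc3)cc2[C@@H](O)C1`: > 100000 nM
Compound 2 `Cc1cccc(COc2ccc3c(c2)[C@@H](O)CN(C)C3)c1`: > 50000 nM

In an ADME assay on Vero cells (Chlorocebus sabaeus) for cytotoxicity, read by sulforhodamine B assay, with a stated time of 72 h (on this read-out lower numbers stand for stronger inhibition and higher numbers for weaker inhibition), compound 1 gives > 100000 nM, which is a limit of the assay rather than a number. Compound 2 likewise gives > 50000 nM, again a limit. The step that the two limits leave unreadable from compound 1 to compound 2 therefore cannot be sized, because the limit of > 100000 nM in this assay, at which 1 of the 2 values shown sits, and the limit of > 50000 nM in this assay, at which 1 of the 2 values shown sits, are where both values sit. Compound 3 `CN1Cc2ccc(OCC3CCNCC3)cc2[C@@H](O)C1` differs from compound 1 by piperidin-4-yl in place of phenyl on a saturated chain carbon bound to an oxygen on an aromatic ring. Among the compounds with values here, no measured step covers this change, and compound 1 itself stands only at a limit. Compound 3 is expected to give 100000 nM (range 30000 nM to 300000 nM), an expected step of a number no higher from compound 1 to compound 3 (the limit leaves the size open), most likely reported only as a limit.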

Compound 3, half-maximal inhibitory concentration: > 100000 nM
Compound 3 was reported as a limit (the forecaster's own chance of this, stated with the estimate: 80%); the middle value sits exactly at the limit.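

Within the data shown here, compound 1, compound 2 and compound 3 all stand at limits in this assay, and no step between them can be read. The compounds shown leave open whether piperidin-4-yl in place of phenyl changes cytotoxicity at all.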